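This account rests on a few compounds, and the source may have more. Where it says the series, first, only, none or still open, it means among the compounds named here.

Three chain-linked analogues share one core, a chromone bearing a phenyl group, a hydroxyl and a methoxy group, with a basic amine hung from an ether chain. Compound 1 `COc1cc2oc(-c3ccccc3)cc(=O)c2c(O)c1OCCCCN1CCN(C)CC1` carries a four-carbon chain ending in a methylpiperazine; in a functional assay on BCG823 cells (Homo sapiens) for antiproliferative activity, read by MTT assay, with a stated time of 48 h (on this read-out higher numbers stand for weaker inhibition and lower numbers for stronger inhibition), compound 1 gives 53500 nM. Compound 2 `CCN(CC)CCCCOc1c(OC)cc2oc(-c3ccccc3)cc(=O)c2c1O` keeps the four-carbon chain but ends in a diethylamine; in this assay compound 2 gives 17400 nM. Compound 3 `COc1cc2oc(-c3ccccc3)cc(=O)c2c(O)c1OCCCN1CCN(C)CC1` shortens the chain by one carbon while keeping the methylpiperazine; in this assay compound 3 gives 31300 nM. The chain shortening, (4-methylpiperazin-1-yl in place of (4-methylpiperazin-1-yl)methyl on a saturated chain carbon, three bonds along the chain from an oxygen on an aromatic ring), produced a 1.7-fold lower number from compound 1 to compound 3 (0.23 log units; within the scatter). Between compound 2 and compound 3 the difference is a 1.8-fold higher number from compound 2 to compound 3 (0.25 log units; within the scatter). The amine swap on the longer chain, (diethylamino in place of 4-methylpiperazin-1-yl on a saturated chain carbon, four bonds along the chain from an oxygen on an aromatic ring), gave a 3.1-fold lower number from compound 1 to compound 2 (0.49 log units; beyond the scatter).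

Compound 4 `CCN(CC)CCCOc1c(OC)cc2oc(-c3ccccc3)cc(=O)c2c1O` has not yet been measured. Within the data shown here, it differs from compound 3 by diethylamino in place of 4-methylpiperazin-1-yl on a saturated chain carbon, three bonds along the chain from an oxygen on an aromatic ring, the same kind of change as the one from compound 1 to compound 2, though here the replacement sits three bonds along the chain from the ring oxygen rather than four. Because the earlier swap gave a 3.1-fold lower number from compound 1 to compound 2 (0.49 log units; beyond the scatter), a step of similar size is expected from compound 3 to compound 4, namely a 3.0-fold lower number from compound 3 to compound 4 (0.47 log units; beyond the scatter), though this rests on a single matched pair. Compound 4 is therefore estimated at 10500 nM in this assay, most likely between 5000 nM and 25000 nM.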

Compound 4, half-maximal inhibitory concentration: 5700 nM
Compound 4: middle estimate off by 1.8-fold (0.27 log units), on the high side, within the range that was stated.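

Replacing 4-methylpiperazin-1-yl with diethylamino lowered the number on both chain lengths, and the two steps agree: the same change on two cores in this assay, a 3.1-fold lower number (0.49 log units; beyond the scatter) from compound 1 to compound 2 and a 5.5-fold lower number (0.74 log units; beyond the scatter) from compound 3 to compound 4, 1.8-fold (0.25 log units) apart, within the scatter of two such steps

The new step, a 5.5-fold lower number from compound 3 to compound 4 (0.74 log units; beyond the scatter), therefore counts as the same change carried to a second core, not as a demonstrably larger effect on the shorter chain. With the diethylamino group kept, shortening the chain gave a 3.1-fold lower number from compound 2 to compound 4 (0.48 log units; beyond the scatter), and changing both the amine and the chain gave a 9.4-fold lower number from compound 1 to compound 4 (0.97 log units; beyond the scatter), so compound 4 has the lowest number of the four, a result that holds only in this assay. These two pairs show that the swap transfers between cores that differ only in chain length, but they do not show that it would transfer to a core changed elsewhere, and they do not explain why diethylamino gives the lower number.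

The compounds shown leave open whether another amine, such as a morpholine, a piperidine or a dimethylamine, would follow diethylamino or 4-methylpiperazin-1-yl. They also leave open whether a still shorter or a longer chain would continue the difference seen here, and whether the same order would appear in other cell lines.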